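Ester of Compound 1: Expectation Before Measurement

This account rests on a few compounds, and the source may have more. Where it says the series, first, only, none or still open, it means among the compounds named here.

Measured compounds:
compound 1 `COc1cc(/C=C/C(=O)O)ccc1OC(=O)c1nc(C)c(C)nc1C` 40.3%
compound 2 `COc1cc(/C=C/C(=O)O)cc(OC)c1OC(=O)c1nc(C)c(C)nc1C` 24%
compound 3 `Cc1nc(C)c(C(=O)Oc2ccc(/C=C/C(=O)O)cc2)nc1C` 46.6%

In a functional assay on EA.hy 926 cells (Homo sapiens) for cytotoxicity, read by MTT assay, with stated times of 24 h and 12 h, tested at 25 uM (a higher number here means a stronger effect of the compound at the concentration tested, a lower number a weaker effect), compound 1 gives 40.3%, the second highest of the three numbers. Compound 3 sits nearest, a number 6.3 percentage points higher from compound 1 to compound 3 (within the scatter), a gap within the scatter, while compound 2 lies furthest, a number 16.3 percentage points lower from compound 1 to compound 2 (beyond the scatter), a modest fall beyond the scatter.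

Compound 4 `CCOC(=O)/C=C/c1ccc(OC(=O)c2nc(C)c(C)nc2C)c(OC)c1` is the next candidate. It differs from compound 1 by ethyl in place of hydrogen on an oxygen next to a carbonyl group. Neither measured step bears on this change: both concern a methoxy on an aromatic carbon, not the acid oxygen. For the measured compounds named here, with no guiding step, a change of no clear direction is expected, and the estimate for compound 4 is a number 0.3 percentage points lower from compound 1 to compound 4 (within the scatter), giving 40% with a range from 22% to 58%.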

Compound 4, a percentage reported as activity, at one concentration (the size of the read-out at that concentration, not a potency): 53.3%
The estimate for compound 4 lay 13.3 percentage points below the measured number; the range from low to high includes it.
By their numbers in this assay, from the lowest: compound 2; then compounds 1, 3 and 4 (each within the scatter of the next, the first and the last beyond it).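

For the compounds shown here, putting ethyl on the oxygen next to the carbonyl group, which turns carboxy into ethoxycarbonyl, is the first change away from the methoxy groups, and in this assay it gives a number 13 percentage points higher from compound 1 to compound 4 (beyond the scatter). The free carboxy hydrogen is therefore not needed for this read-out on the core of compound 1. Nothing available explains the rise.

Going by these compounds, whether a methyl group, a longer chain such as butyl, or an amide in place of the ester would follow the same direction stays open. So does whether ethyl has a similar effect on the cores of compound 2 and compound 3.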